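The source may hold more compounds than are shown below. What is called first, only, known or untested is meant among the compounds shown, and "the series" means these compounds.

Measured compounds:
compound 1 `Cc1ccccc1CN1CCN(C(=O)CN[C@H]2CCN(S(=O)(=O)Cc3ccccc3)C2)CC1`: 10200 nM
compound 2 `COc1cccc(CN2CCN(C(=O)CN[C@H]3CCN(S(=O)(=O)Cc4ccccc4)C3)CC2)c1`: 60800 nM

Both were tested in a functional assay on K562 cells (Homo sapiens) for cytotoxicity, read by MTT assay, with a stated time of 48 h; on this read-out lower numbers stand for stronger inhibition and higher numbers for weaker inhibition. Among these two, compound 2 has the higher number, and the step of a 6.0-fold higher number from compound 1 to compound 2 (0.78 log units; beyond the scatter) sets it apart from compound 1. The unmeasured compound 3 `COc1cc(CN2CCN(C(=O)CN[C@H]3CCN(S(=O)(=O)Cc4ccccc4)C3)CC2)cc(OC)c1OC` differs from compound 2 in one place: 3,4,5-trimethoxyphenyl in place of 3-methoxyphenyl on a saturated chain carbon bound to an amine nitrogen in a ring. For the measured compounds named here, no measured pair shows this exact exchange, so the only step that bears on it is a 6.0-fold higher number from compound 1 to compound 2 (0.78 log units; beyond the scatter), which swapped one aryl group for another at the same place and moved the number by a modest amount. Adding two more methoxy groups to the same ring is a smaller change of kind, and the expected step of a 1.1-fold lower number from compound 2 to compound 3 (0.04 log units; within the scatter) is therefore not beyond the scatter. The estimate for compound 3 in this assay is 55000 nM, in the expected range 15000 nM to 150000 nM.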

Compound 3, half-maximal inhibitory concentration: 93000 nM
The estimate for compound 3 lay 1.7-fold (0.23 log units) below the measured number; low and high end bracket the measured number.
By their numbers in this assay, from the lowest: compound 1; then compounds 2 and 3 (each within the scatter of the next).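

In this assay, 3,4,5-trimethoxyphenyl in place of 3-methoxyphenyl gives a 1.5-fold higher number from compound 2 to compound 3 (0.18 log units; within the scatter), so this assay cannot tell these two groups apart at this position, even though the entering group is larger, with more oxygen atoms and hydrogen-bond acceptors. The 2-methylphenyl of compound 1 remains separate from the new group, with a 9.1-fold higher number from compound 1 to compound 3 (0.96 log units; beyond the scatter), so among these three compounds, the two with methoxy-bearing rings both have clearly higher numbers than the one with the methyl-bearing ring. No available measurement explains this grouping.

From the compounds shown here alone, it remains open where an unsubstituted phenyl would fall, and whether it would sit with compound 1 or with compound 2 and compound 3. Going by these compounds, a ring carrying an amine or a carboxylic acid at the same place also remains untested by these compounds.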